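Chloro to bromo: one halogen replaced by another

The source may report more compounds than this note shows. Statements on the series, on what has been measured and on what is new or still open speak of the compounds shown alone.

Compound 1, `c1ccc(-c2cn3ccnc3c(-c3ccc4ncn(C5CCCCC5)c4c3)n2)cc1`: 37.3%
Compound 2, `Clc1ccc(-c2cn3ccnc3c(-c3ccc4ncn(C5CCCCC5)c4c3)n2)cc1`: 11.3%

Within the data shown here, in a functional assay on U-251 cells (Homo sapiens) for inhibition, read by sulforhodamine B assay, with a stated time of 48 h, tested at 10 uM (a lower number here means less inhibition, a higher number more inhibition at the concentration tested (going by the name of the read-out)), compound 2 gives 11.3%, the lowest of the two numbers measured, with compound 1 as its only neighbour. Among the measured compounds shown here, the one measured step is a number 26 percentage points lower from compound 1 to compound 2 (beyond the scatter). Compound 3, `Brc1ccc(-c2cn3ccnc3c(-c3ccc4ncn(C5CCCCC5)c4c3)n2)cc1`, differs from compound 2 by bromo in place of chloro on an aromatic carbon. For the measured compounds named here, no measured step swaps one halogen for another, so the earlier step only shows that the number is lower with chloro on this carbon than with hydrogen. A step no larger than the usual scatter is therefore expected, a number 2.7 percentage points higher from compound 2 to compound 3 (within the scatter). Compound 3 is estimated at 14%, with a range from 0% to 32%.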

Compound 3, a percentage reported as inhibition, at one concentration (the size of the read-out at that concentration, not a potency): 23.7%
Estimate against measurement, compound 3: 9.7 percentage points below, and the stated range covers the measured number.
By their numbers in this assay, from the lowest: compound 2; then compound 3; then compound 1.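

In this assay, swapping one halogen for the other matters at this carbon: the change from 4-chlorophenyl to 4-bromophenyl gives a number 12.4 percentage points higher from compound 2 to compound 3 (beyond the scatter), so here the two halogens are not interchangeable. Bromo still stands below hydrogen, with a number 13.6 percentage points lower from compound 1 to compound 3 (beyond the scatter), so both halogens lower the number, but by different amounts. Nothing measured here explains the gap between chloro and bromo. From the compounds shown here alone, whether fluoro, a methoxy group or an amine on this carbon would fall in the same range remains open, as does whether chloro and bromo would differ in the same way elsewhere on this ring.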